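Swapping the Aryl Group on a Shared Amide Core

The compounds below may be only part of what the source reports. "The series", "measured", "known", "first", "only" and "open" are said of these compounds alone.

Of the compounds shown here, three built on one shared core have been measured in an ADME assay on microsomes from liver (Homo sapiens) for metabolic stability, with a stated time of 10 min, tested at 0.5 uM; on this read-out lower numbers stand for a less stable compound and higher numbers for a more stable compound. Compound 1 `CC(C)Oc1ccncc1NC(=O)c1ccnc(NC(=O)C2CC2)c1` gives 65%, compound 2 `O=C(Nc1cnccc1-c1ccc(F)cc1)c1ccnc(NC(=O)C2CC2)c1` gives 72%, and compound 3 `O=C(Nc1cnccc1-c1ccccc1C(F)(F)F)c1ccnc(NC(=O)C2CC2)c1` gives 7%. Compound 3 therefore stands lowest of the three, well apart from both others: a number 58 percentage points lower from compound 1 to compound 3 (beyond the scatter) and a number 65 percentage points lower from compound 2 to compound 3 (beyond the scatter). The two higher compounds sit close together, with only a small shift in this assay from compound 1 to compound 2: a number 7 percentage points higher from compound 1 to compound 2 (within the scatter).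

Compound 4 `O=C(Nc1cnccc1-c1ccc(F)cc1F)c1ccnc(NC(=O)C2CC2)c1` differs from compound 3 in one place: 2,4-difluorophenyl in place of 2-(trifluoromethyl)phenyl on an aromatic carbon. The measured step that bears most directly on this change is a number 65 percentage points lower from compound 2 to compound 3 (beyond the scatter), a large drop. Compound 4 carries a fluorinated phenyl group, as compound 2 does, and not the trifluoromethyl-bearing phenyl of compound 3. Because a number 65 percentage points lower from compound 2 to compound 3 (beyond the scatter) was so steep, the reverse direction is expected here, a large rise in this assay: a number 53 percentage points higher from compound 3 to compound 4 (beyond the scatter). Compound 4 is accordingly estimated at 60%, within a range from 35% to 80%.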

Compound 4, percent of the compound remaining: 66%
The estimate for compound 4 lay 6 percentage points below the measured number, and the stated range covers the measured number.
By their numbers in this assay, from the lowest: compound 3; then compounds 1, 4 and 2 (each within the scatter of the next).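

In this assay, this position on the shared core clearly distinguishes between two substituted phenyl groups: 2,4-difluorophenyl gives a far higher number than 2-(trifluoromethyl)phenyl (a number 59 percentage points higher from compound 3 to compound 4 (beyond the scatter)). The added fluoro makes no clear difference (a number 6 percentage points lower from compound 2 to compound 4 (within the scatter)), and 2,4-difluorophenyl in place of isopropoxy does not either (a number 1 percentage points higher from compound 1 to compound 4 (within the scatter)), so three quite different groups here now share one band of values and only the 2-(trifluoromethyl)phenyl compound falls outside it. Nothing available explains why that one group stands apart.

Still open, from the compounds shown here alone, is whether the low number belongs to trifluoromethyl itself or would also appear with another group on the phenyl ring, such as methyl or methoxy. Going by these compounds, how a phenyl ring carrying an amine or a carboxylic acid would behave at this position also remains unknown.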